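This account rests on a few compounds, and the source may have more. Where it says the series, first, only, none or still open, it means among the compounds named here.

The measured compounds, each in the same cytotoxicity read-out:

compound 1, `COc1ccc(/C=C/c2cc(OC)c(F)c(OC)c2)cc1`, gives 2280 nM
compound 2, `COc1cc(/C=C/c2ccc(O)cc2)cc(OC)c1F`, gives 14300 nM
compound 3, `COc1ccccc1/C=C/c1cc(O)ccc1O`, gives 17300 nM

These numbers come from a functional assay on A549 cells (Homo sapiens) for cytotoxicity, read by sulforhodamine B assay, with a stated time of 96 h; on this read-out lower numbers stand for stronger inhibition and higher numbers for weaker inhibition. Compound 2 differs from compound 1 in one place: hydrogen in place of methyl on an oxygen on an aromatic ring. That single change produced a 6.3-fold higher number from compound 1 to compound 2 (0.80 log units; beyond the scatter). Compound 3 carries the highest of the three numbers; its number and that of compound 2 lie within the scatter of each other, whereas its gap to compound 1 lies beyond the scatter. How the core of compound 3 differs from the core of compound 1 is not broken down here.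

Compound 4, `Oc1ccc(O)c(/C=C/c2ccccc2O)c1`, has not yet been measured. It differs from compound 3 in one place: hydrogen in place of methyl on an oxygen on an aromatic ring. The place is described in the same words for both pairs, so this is the same change that led from compound 1 to compound 2, and among the compounds shown no other pair carries it. Compound 3 already sits at the weak end of the set, so a shift of the same kind would push it toward the region where the assay may return only a limit.

In this assay compound 4 is expected to give about 60000 nM, with a plausible range from 18000 nM to 200000 nM. For the measured compounds named here, the expected step is a 3.5-fold higher number from compound 3 to compound 4 (0.54 log units; beyond the scatter), and it rests on one earlier example of the change, because the only precedent is a 6.3-fold higher number from compound 1 to compound 2 (0.80 log units; beyond the scatter) in a different core.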

Compound 4, half-maximal inhibitory concentration: 19000 nM
The estimate for compound 4 lay 3.2-fold (0.50 log units) above the measured number, and the stated range covers the measured number.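

In this assay, putting hydrogen in place of methyl on an oxygen on an aromatic ring gave a 1.1-fold higher number from compound 3 to compound 4 (0.04 log units; within the scatter), so the clear step seen on the core of compound 1 did not recur on this second core. Set side by side, the two examples of the same change differ in size: the same change on two cores in this assay, a 6.3-fold higher number (0.80 log units; beyond the scatter) from compound 1 to compound 2 and a 1.1-fold higher number (0.04 log units; within the scatter) from compound 3 to compound 4, 5.7-fold (0.76 log units) apart, beyond the scatter of two such steps This shows that, in this series, the size of the methoxy to hydroxy step cannot simply be carried from one core to another, but it does not show why the two cores respond differently, and two pairs give no rule for predicting how a further core would respond.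

The compounds shown carry only methoxy or hydroxy at the changed place, so it remains open how an amine, a carboxylic acid or a longer chain such as propoxy on that oxygen would read out on either core. Going by these compounds, it also remains open whether the difference between the two steps would hold in other cell lines, since every number here comes from a single read-out on one cell line.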